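The source may report more compounds than this note shows. Statements on the series, on what has been measured and on what is new or still open speak of the compounds shown alone.

Measured in a functional assay on MCF7 cells (Homo sapiens) for cytotoxicity, read by MTT assay, with a stated time of 72 h; on this read-out higher numbers stand for weaker inhibition and lower numbers for stronger inhibition: compound 1 `Cc1ccnc(/C(N)=N/NC(=S)N2CCCCCC2)c1` gives 6900 nM; compound 2 `N/C(=N\NC(=S)N1CCCCCC1)c1ccccn1` gives 2600 nM; compound 3 `Cc1ccnc(/C(N)=N/NC(=S)N2CCN(c3ccccn3)CC2)c1` gives 12300 nM.

Among these three, compound 3 carries the highest number. Its nearest neighbour is compound 1, whose value sits within the scatter of it, while compound 2 lies furthest off, beyond the scatter. Compound 4 `N/C(=N\NC(=S)N1CCN(c2ccccn2)CC1)c1ccccn1` is unmeasured and differs from compound 3 by one change: hydrogen in place of methyl on an aromatic carbon. Within the data shown here, the only measured step that bears on this change is a 2.7-fold lower number from compound 1 to compound 2 (0.42 log units; beyond the scatter), which is the same replacement on the same ring in a closely related pair. A downward step of comparable size is therefore expected, a 2.7-fold lower number from compound 3 to compound 4 (0.44 log units; beyond the scatter). Compound 4 is estimated at 4500 nM, with a range from 2000 nM to 10000 nM.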

Compound 4, half-maximal inhibitory concentration: 13700 nM
For compound 4 the middle estimate is 3.0-fold (0.48 log units) below the measured one, outside the stated range (above it).
By their numbers in this assay, from the lowest: compound 2; then compounds 1, 3 and 4 (each within the scatter of the next).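

In this assay the change from 4-methylpyridin-2-yl to pyridin-2-yl gives a 1.1-fold higher number from compound 3 to compound 4 (0.05 log units; within the scatter) and so leaves no readable difference on this core, where the methyl is opposite the ring nitrogen. The earlier pair alone suggested that losing this methyl lowers the number, but that holds only for the core of compound 1. The same change therefore does not carry over unchanged from one core to the other: the same change on two cores in this assay, a 2.7-fold lower number (0.42 log units; beyond the scatter) from compound 1 to compound 2 and a 1.1-fold higher number (0.05 log units; within the scatter) from compound 3 to compound 4, 3.0-fold (0.47 log units) apart, beyond the scatter of two such steps

What the compounds shown leave open is how a methoxy, a chlorine or an amine at this position would read on either core. They also leave open why the two cores part, and whether either behaviour extends to other groups on the thiocarbonyl nitrogen.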